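The source may hold more compounds than are shown below. What is called first, only, known or untested is meant among the compounds shown, and "the series" means these compounds.

Three measured compounds, compound 1 `CCCC(CCC)Nc1nc(C)nc2c1nnn2-c1c(C)cc(C)cc1C`, compound 2 `CCN(CC)c1nc(C)nc2c1nnn2-c1ccc(C(C)C)cc1Br` and compound 3 `CCCCc1nc2c(N(CC)CCCC)nc(C)nc2n1-c1c(Cl)cc(OC)cc1OC`, were run in an in vitro assay on 293-EBNA cells for binding affinity to corticotropin-releasing factor receptor 1 (Homo sapiens); a lower number here means a stronger inhibitor, a higher number a weaker inhibitor. Compound 1 gives 4 nM, compound 2 gives 25.3 nM and compound 3 gives 22 nM. Compound 2 has the highest number of the three; its gap to compound 3 lies within the scatter, while its gap to compound 1 lies beyond it. Compound 4 `CCC(COC)Oc1nc(C)nc2c1nnn2-c1ccc(C(C)C)cc1Br` has not yet been measured in this assay. It differs from compound 2 by a single change, (1-(methoxymethyl)propoxy in place of diethylamino on an aromatic carbon). Among the compounds with values here, no measured pair isolates this change, so the step can only be anticipated: it is expected to be a 2.4-fold higher number from compound 2 to compound 4 (0.38 log units; beyond the scatter), of moderate size and toward a weaker inhibitor. Compound 4 is accordingly estimated at 60 nM, within a range from 15 nM to 250 nM.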

Compound 4, inhibition constant: 1.9 nM
Estimate against measurement, compound 4: 32-fold (1.50 log units) above; the measured number lies below the stated range.
By their numbers in this assay, from the lowest: compound 4; then compound 1; then compounds 3 and 2 (each within the scatter of the next).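

In this assay, 1-(methoxymethyl)propoxy in place of diethylamino on this aromatic carbon, next to the ring nitrogen, gives a 13-fold lower number from compound 2 to compound 4 (1.12 log units; beyond the scatter). The position therefore responds strongly to the group it carries, and the group that enters here holds two oxygens and no nitrogen. Nothing available explains the size of this step. The compounds shown leave open which feature of the entering group goes with the lower number. A plain propoxy group or a 1-(methoxymethyl)propylamino group at this place would help separate these features.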